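The compounds below may be only part of what the source reports. "The series", "measured", "known", "first", "only" and "open" are said of these compounds alone.

Within the data shown here, compound 1, with the structure `CCCc1cc(N)c2cc(NC(=O)/C=C/c3ccc(N)cc3)ccc2n1`, is the only compound in this set with a measured number. In an assay on isolated protein for displacement of a labelled ligand from melanin-concentrating hormone receptor 1 (Homo sapiens) (a higher number here means a weaker inhibitor, a lower number a stronger inhibitor), compound 1 gives 190 nM. Among the measured compounds shown here, compound 2, with the structure `CCCc1cc(N2CCCCC2)c2cc(NC(=O)/C=C/c3ccc(C(F)(F)F)cc3)ccc2n1`, differs from compound 1 in two places at once, so no single step connects them. In this assay compound 2 reaches only a limit, > 4000 nM, which means that the limit of > 4000 nM in this assay, at which 1 of the 2 values shown sits, is all that can be said of it and no number is known. Compound 3, with the structure `CCCc1cc(N)c2cc(NC(=O)/C=C/c3ccc(Cl)c(Cl)c3)ccc2n1`, has not yet been measured in this assay. It differs from compound 1 by one change: 3,4-dichlorophenyl in place of 4-aminophenyl on a double-bonded chain carbon bound to a double-bonded chain carbon. For the measured compounds named here, no measured pair isolates this kind of change, so the account gives only an expectation. The step from compound 1 to compound 3 is expected to be small, near the scatter, with a mild lean toward weaker binding, a 1.6-fold higher number from compound 1 to compound 3 (0.20 log units; within the scatter). Compound 3 is therefore estimated in this assay at 300 nM, within a range from 60 nM to 1500 nM.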

Compound 3, half-maximal inhibitory concentration: 60 nM
Estimate against measurement, compound 3: 5.0-fold (0.70 log units) above; low and high end bracket the measured number.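

In this assay, among these compounds, 3,4-dichlorophenyl in place of 4-aminophenyl on a double-bonded chain carbon bound to a double-bonded chain carbon gives a 3.2-fold lower number from compound 1 to compound 3 (0.50 log units; beyond the scatter), the first readable step in this set, and it shows that this position responds to the choice of aromatic group. The group that leaves counts a hydrogen-bond donor and acceptor and the group that enters counts neither, so in this pair the lower number goes with the group lacking them. Nothing measured here gives a cause for this step.

On these data alone, whether one chlorine would suffice, as in 4-chlorophenyl, or whether a carboxylic acid on this ring would be accepted stays open. Compound 2 stands only at a limit, > 4000 nM, and it differs from compound 3 in more than one place, so it cannot settle either question.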